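Ether variation on the shared core: cytotoxicity outlook

This account rests on a few compounds, and the source may have more. Where it says the series, first, only, none or still open, it means among the compounds named here.

Compound 1 `O=C(Nc1ncc(Cc2ccc(F)cc2)s1)c1ccccc1` is the simplest member of this small set. In an ADME assay on HepG2 2.2.15 cells (Homo sapiens) for cytotoxicity (a higher number here means that more compound is tolerated, a lower number that less compound is tolerated), compound 1 is recorded as "not toxic" (no number reported). Compound 2 `CC(C)(C)OC(=O)Nc1ncc(C(Oc2ccc(Br)cc2)c2ccc(Cl)cc2)s1` and compound 3 `CC(C)(C)OC(=O)Nc1ncc(C(Oc2cccc(C#N)c2)c2ccc(Cl)cc2)s1` share a core on which a carbamate and a diaryl-substituted saturated carbon bearing an aryl ether are present. In this assay compound 2 reaches only the limit of the measurement, > 50000 nM. Compound 3 likewise gives only a limit in this assay, > 50000 nM. The step that the two limits leave unreadable from compound 2 to compound 3 therefore cannot be read, and compound 3 stands, like compound 2, at the point described by the limit of > 50000 nM in this assay, at which 2 of the 3 values shown sit; with the remaining entry carrying no number, nothing in the set sits at a readable value.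

Compound 4 `CC(C)(C)OC(=O)Nc1ncc(C(Oc2ccc3cc(Br)ccc3c2)c2ccc(Cl)cc2)s1` differs from compound 3 by 6-bromonaphthalen-2-yl in place of 3-cyanophenyl on an oxygen on a saturated carbon. Within the data shown here, the only step measured on this ether, a step that the two limits leave unreadable from compound 2 to compound 3, lies between two limits and so shows no readable size. Among the measured compounds shown here, with no measured step of readable size bearing on the change, compound 4 is expected to remain near the limit in this assay, and the step that the limit leaves unreadable from compound 3 to compound 4 is estimated to be none beyond the scatter. The estimate for compound 4 is 60000 nM, with a range from 20000 nM to 200000 nM.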

Compound 4, half-maximal cytotoxic concentration: > 50000 nM
Compound 4: only a limit was reported; the forecaster's own chance of this, stated with the estimate: 80%; the middle value lies beyond the limit too.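

Compound 4 also gives only a limit in this assay, > 50000 nM, so neither the step from compound 3 to compound 4 nor that from compound 2 to compound 4 can be read. The compounds shown leave open how much of each of these three ethers is tolerated in this assay, and whether changing the aryl group on the ether oxygen alters that tolerance at all.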